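Pyrazole carboxylic acids binding Mdm2: isopropoxy to benzyloxy

A few compounds are considered here, and "the series" means these few. Any claim that something is new, unique, unknown or untested is made for them only; others in the source may bear on it.

Compound 1 `CC(C)Oc1ccc(-c2cc(C(=O)O)nn2-c2ccccc2)cc1` and compound 2 `O=C(O)c1cc(-c2ccc(OCc3ccccc3)cc2)n(-c2ccccc2)n1` share a small core; compound 3 `CC(C)Oc1ccc(C(=O)Nc2c(C(=O)O)nn(-c3ccc(Oc4ccccc4)cc3)c2-c2ccc(OC(C)C)cc2)cc1` and compound 4 `CC(C)Oc1ccc(C(=O)Nc2c(C(=O)O)nn(-c3ccc(Oc4ccccc4)cc3)c2-c2ccc(OCc3ccccc3)cc2)cc1` share a larger one. The difference between the two cores is not broken down here. In an assay for displacement of a labelled ligand from E3 ubiquitin-protein ligase Mdm2 (Homo sapiens), read by fluorescence polarization, with a stated time of 30 min (a lower number here means a stronger inhibitor, a higher number a weaker inhibitor), compound 1 gives 2290 nM, compound 2 gives 19800 nM, and compound 3 gives 107 nM, the lowest of the three numbers. The change benzyl in place of isopropyl on an oxygen on an aromatic ring gave an 8.6-fold higher number from compound 1 to compound 2 (0.94 log units; beyond the scatter). The change benzyl in place of isopropyl on an oxygen on an aromatic ring is the same change, at the same kind of place. Within the data shown here, compound 4 is therefore expected to be a weaker inhibitor than compound 3, with an expected step of about a 6.5-fold higher number from compound 3 to compound 4 (0.82 log units; beyond the scatter), resting on the single earlier step from compound 1 to compound 2. The cores differ, and the expectation is read with caution. In this assay compound 4 is estimated at 700 nM, within 200 nM to 2500 nM.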

Compound 4, inhibition constant: 4470 nM
For compound 4 the middle estimate is 6.4-fold (0.81 log units) below the measured one, outside the stated range (above it).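

In this assay, benzyl in place of isopropyl on an oxygen on an aromatic ring gives a higher number on both cores, and on the larger core the step is a 42-fold higher number from compound 3 to compound 4 (1.62 log units; beyond the scatter). The direction of the change carries from one core to the other, but its size does not: the same change on two cores in this assay, an 8.6-fold higher number (0.94 log units; beyond the scatter) from compound 1 to compound 2 and a 42-fold higher number (1.62 log units; beyond the scatter) from compound 3 to compound 4, 4.8-fold (0.68 log units) apart, beyond the scatter of two such steps. These two pairs do not show why the size differs, nor how the change would behave on a third core.

The compounds shown leave open how either core would respond to a different group on that oxygen, such as ethyl or cyclopropylmethyl. They also leave open whether an amine on the benzyl ring would alter the step.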